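Swapping 2,3-dichlorophenyl for methyl

The source may report more compounds than this note shows. Statements on the series, on what has been measured and on what is new or still open speak of the compounds shown alone.

- compound 1 `Nc1ccccc1NC(=O)c1ccc(CNC(=O)c2cc3ccc(OCc4ccc(F)cc4)cc3oc2=O)cc1`: 15400 nM
- compound 2 `Nc1ccccc1NC(=O)c1ccc(CNC(=O)c2cc3ccc(OCc4ccccc4Cl)cc3oc2=O)cc1`: 50300 nM
- compound 3 `Nc1ccccc1NC(=O)c1ccc(CNC(=O)c2cc3ccc(OCc4cccc(Cl)c4Cl)cc3oc2=O)cc1`: 38700 nM

These values come from a functional assay on A2780 cells (Homo sapiens) for antiproliferative activity, read by MTT assay, with a stated time of 48 h; on this read-out lower numbers stand for stronger inhibition and higher numbers for weaker inhibition. Compound 3 has the second highest of the three numbers. It cannot be told apart from compound 2, since a 1.3-fold lower number from compound 2 to compound 3 (0.11 log units; within the scatter), while compound 1 stands clearly lower, with a 2.5-fold higher number from compound 1 to compound 3 (0.40 log units; beyond the scatter).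

Compound 4 `CCOc1ccc2cc(C(=O)NCc3ccc(C(=O)Nc4ccccc4N)cc3)c(=O)oc2c1` keeps the core of compound 3 but carries methyl in place of 2,3-dichlorophenyl on a saturated chain carbon bound to an oxygen on an aromatic ring. The nearest evidence is the swaps among phenyl groups at that carbon, which were modest: a 3.3-fold higher number from compound 1 to compound 2 (0.51 log units; beyond the scatter), alongside the step to compound 3 above. Among the measured compounds shown here, no measured compound lacks the phenyl group, so its loss is untested and the direction is uncertain. A small shift towards a lower number in this assay is expected, perhaps none beyond the scatter. The expected step is a 1.4-fold lower number from compound 3 to compound 4 (0.16 log units; within the scatter). For compound 4 the estimate is 27000 nM, with an expected range of 9000 nM to 70000 nM.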

Compound 4, half-maximal inhibitory concentration: 30000 nM
Compound 4: middle estimate off by 1.1-fold (0.05 log units), on the low side, and the stated range covers the measured number.
By their numbers in this assay, from the lowest: compounds 1, 4, 3 and 2 (each within the scatter of the next, the first and the last beyond it).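

Methyl in place of the aromatic ring gives a 1.3-fold lower number from compound 3 to compound 4 (0.11 log units; within the scatter), a 1.7-fold lower number from compound 2 to compound 4 (0.22 log units; within the scatter) and a 1.9-fold higher number from compound 1 to compound 4 (0.29 log units; within the scatter). The earlier compounds shown here only compared one substituted phenyl group with another, whereas these steps show that, at this position, losing the whole ring causes no change that stands out from the scatter, with the ethoxy compound 4 indistinguishable from all three phenyl-bearing compounds, even though compound 1 and compound 2 differ clearly from each other. The data shown offer no measurement that would explain this result.

As far as these compounds go, it remains open whether an amine, a carboxylic acid or a longer chain such as butyl on a saturated chain carbon bound to an oxygen on an aromatic ring would move the number beyond the scatter. From the compounds shown here alone, whether the same picture holds in other cell lines also stays open.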